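Swapping a Methoxyphenyl for a Furan in a Chalcone

The source may report more compounds than this note shows. Statements on the series, on what has been measured and on what is new or still open speak of the compounds shown alone.

Compound 1 `C=CCOc1cc(OC)c(C(=O)/C=C/c2cccc(OC)c2)c(OCC=C)c1` was tested in an ADME assay on Vero cells (Chlorocebus sabaeus) for cytotoxicity, read by MTT assay (a higher number here means a weaker inhibitor, a lower number a stronger inhibitor), and gave 142000 nM. Of the two numbers recorded in this assay, that of compound 1 is the highest, so among the measured compounds it is the weakest at reducing the viability of the cells. Its nearest neighbour is compound 3 `C=CCOc1cc(OC)c(C(=O)/C=C/c2cc(OC)c(OC)c(OC)c2)c(OCC=C)c1`, which in this assay gives 40900 nM, a number enough lower than that of compound 1 to lie beyond the usual scatter of repeated measurements. Compound 2 `COc1ccc(/C=C/C(=O)c2c(O)cc(O)cc2OC)cc1` also belongs to the set, but in this assay compound 2 has only "not determined" (no result reported), so no number was reported for it. Compound 4 `C=CCOc1cc(OC)c(C(=O)/C=C/c2ccco2)c(OCC=C)c1` differs from compound 1 in a single place: furan-2-yl in place of 3-methoxyphenyl on a double-bonded chain carbon bound to a double-bonded chain carbon. For the measured compounds named here, no step between two measured compounds shows what this exchange alone does, so there is no direct guide. The expectation is a step from compound 1 to compound 4 of a 1.2-fold lower number from compound 1 to compound 4 (0.07 log units; within the scatter), which means little or no change beyond the scatter. Compound 4 is therefore estimated at 120000 nM, within a range from 50000 nM to 300000 nM.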

Compound 4, half-maximal inhibitory concentration: 191000 nM
Compound 4: the middle estimate sits 1.6-fold (0.20 log units) below what was measured; low and high end bracket the measured number.
By their numbers in this assay, from the lowest: compound 3; then compounds 1 and 4 (each within the scatter of the next).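

In this assay, for the compounds shown here, the exchange of 3-methoxyphenyl for furan-2-yl on a double-bonded chain carbon gives the first direct reading at this position: a 1.3-fold higher number from compound 1 to compound 4 (0.13 log units; within the scatter) is a step within the scatter. So a six-membered carbon ring of 8 heavy atoms and a five-membered ring of 5 heavy atoms with 1 hetero atom cannot be told apart here, even though the entering group is smaller and of a different ring type. No measurement at hand accounts for this result.

The compounds shown leave open whether any group at this place can move the number beyond the scatter, for instance an amine or a carboxylic acid in place of furan-2-yl. They also leave open whether furan-2-yl and 3-methoxyphenyl would match as closely on a different core.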